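The compounds below may be only part of what the source reports. "The series", "measured", "known", "first", "only" and "open" are said of these compounds alone.

Measured in a functional assay on UACC-62 cells (Homo sapiens) for inhibition, read by sulforhodamine B assay, with a stated time of 48 h; on this read-out lower numbers stand for stronger inhibition of growth and higher numbers for weaker inhibition of growth:
compound 1 `O=C(Nc1cccc(-n2cc(-c3ccncc3)c(-c3ccc(Cl)c(O)c3)n2)c1)Nc1cccc(C(F)(F)F)c1` gives 6910 nM
compound 2 `O=C(Nc1cccc(-n2cc(-c3ccncc3)c(-c3ccc(Cl)c(O)c3)n2)c1)Nc1ccc(Cl)c(Cl)c1` gives 5210 nM
compound 3 `COc1cc(-c2nn(-c3cccc(NC(=O)Nc4ccc(Cl)c(C(F)(F)F)c4)c3)cc2-c2ccncc2)ccc1Cl` gives 2090 nM

Compound 3 stands lowest of the three numbers in this assay. Compound 2 is its nearest neighbour and compound 1 the furthest, and both gaps lie beyond the scatter.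

Compound 4 `O=C(Nc1cccc(-n2cc(-c3ccncc3)c(-c3ccc(Cl)c(O)c3)n2)c1)Nc1ccc(Cl)c(C(F)(F)F)c1` differs from compound 3 by hydrogen in place of methyl on an oxygen on an aromatic ring. Among the measured compounds shown here, no measured step covers this change. For the measured compounds named here, the one measured step, a 1.3-fold lower number from compound 1 to compound 2 (0.12 log units; within the scatter), sits at the aryl on the other urea nitrogen and is within the scatter, so it tells nothing about the oxygen. Going by the values given here, compounds 1 and 2 carry the hydroxy group that compound 4 carries, and both give higher numbers than compound 3, yet each also differs from compound 3 at the aryl on the urea, so their values show only that the two hydroxy analogues measured so far sit above the methoxy analogue. On that basis a moderate rise in the number is expected for compound 4, a 1.9-fold higher number from compound 3 to compound 4 (0.28 log units; within the scatter), landing between compound 3 and compounds 1 and 2. The estimate for compound 4 is 4000 nM, with a range from 1500 nM to 11000 nM.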

Compound 4, concentration for total growth inhibition: 1450 nM
For compound 4 the middle estimate is 2.8-fold (0.44 log units) above the measured one; the whole stated range lies above it.
By their numbers in this assay, from the lowest: compounds 4 and 3 (each within the scatter of the next); then compounds 2 and 1 (each within the scatter of the next).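

In this assay, among the compounds shown here, the change from methoxy to hydroxy, 4-chloro-3-methoxyphenyl to 4-chloro-3-hydroxyphenyl, gives a 1.4-fold lower number from compound 3 to compound 4 (0.16 log units; within the scatter), so this single change, which no earlier step covered, does not separate the pair on this read-out. With the hydroxy group held in place, the aryl on the other urea nitrogen does move the number beyond the scatter: trifluoromethyl in place of chloro on an aromatic carbon gives a 3.6-fold lower number from compound 2 to compound 4 (0.56 log units; beyond the scatter), and chloro in place of hydrogen on an aromatic carbon gives a 4.8-fold lower number from compound 1 to compound 4 (0.68 log units; beyond the scatter). No measurement offered here explains either the flat step at the oxygen or the larger steps at the urea aryl.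

For the compounds shown here, the oxygen is seen only with hydrogen and methyl, so it remains open whether a longer chain such as ethyl, or a replacement of the whole hydroxy group by an amine or a carboxylic acid, would also stay within the scatter of compound 4. Also open is whether methoxy and hydroxy stay this close when the urea aryl is that of compound 1 or compound 2, as only one such pair is shown.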